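A few compounds are considered here, and "the series" means these few. Any claim that something is new, unique, unknown or untested is made for them only; others in the source may bear on it.

Of the compounds shown here, three have been measured in a functional assay on MCF7 cells (Homo sapiens) for inhibition, read by sulforhodamine B assay, with a stated time of 48 h; on this read-out higher numbers stand for weaker inhibition of growth and lower numbers for stronger inhibition of growth. Compound 1 `c1ccc2cc(NC3=NCCO3)ccc2c1` gives 4500 nM, and compound 2 `O=C(CCl)NC(=O)Nc1ccc2c(c1)CCC2` gives 4000 nM. Compound 3 `O=C(CCl)NC(=O)Nc1ccc(C2CCCCC2)cc1` gives 1500 nM, the lowest of the three numbers and the strongest inhibition of growth among them, and its distance from each of the other two lies beyond the usual scatter.

The next compound is compound 4 `Cc1ccc(NC(=O)NC(=O)CCl)cc1`, which puts methyl in place of cyclohexyl on an aromatic carbon. The rest of compound 3 stays unchanged. Within the data shown here, no measured pair isolates a change at this position, so the expectation rests on indirect evidence. Compound 2, which also lacks the cyclohexyl, gives 4000 nM, a higher number than compound 3 shows, although that comparison involves a different structure and cannot be read as a clean step.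

In this assay, a move toward weaker inhibition of growth is therefore expected, probably beyond the scatter. The expected change is a 4.0-fold higher number from compound 3 to compound 4 (0.60 log units; beyond the scatter). For compound 4 the estimated value is 6000 nM, with an expected range of 2500 nM to 15000 nM.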

Compound 4, concentration for 50% growth inhibition: 7500 nM
For compound 4 the middle estimate is 1.3-fold (0.10 log units) below the measured one; measured number inside the range.
By their numbers in this assay, from the lowest: compound 3; then compounds 2, 1 and 4 (each within the scatter of the next).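

In this assay, among these compounds, the change of methyl in place of cyclohexyl on an aromatic carbon gives the first reading at this position with the rest of the molecule held fixed, and it brings a 5.0-fold higher number from compound 3 to compound 4 (0.70 log units; beyond the scatter) as a move toward weaker inhibition of growth. The earlier compounds shown here could only hint at this, whereas this pair shows directly that the group at this place affects the read-out, with cyclohexyl giving the stronger inhibition of the two groups. Nothing shown here accounts for the step.

The pair spans only two groups, one a single carbon and the other a six-membered non-aromatic ring of six carbons, so the compounds shown leave open how the read-out moves across the range between them, for instance with an ethyl, a butyl or a cyclopentyl at this place. They also leave open whether a ring is needed at all, which a longer open chain such as hexyl could test, and how an amine or a carboxylic acid would fare on the same aromatic carbon.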